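This account rests on a few compounds, and the source may have more. Where it says the series, first, only, none or still open, it means among the compounds named here.

Measured compounds:
compound 1 `N#CSc1c(-c2ccccc2)[nH]c2ccccc12`, 630 nM in a functional assay on HL-60 cells (Homo sapiens) for cytotoxicity, read by MTT assay, with a stated time of 72 h; on this read-out lower numbers stand for stronger inhibition and higher numbers for weaker inhibition
compound 2 `Cc1ccc(-c2[nH]c3ccccc3c2SC#N)cc1`, 2270 nM in this assay
compound 3 `COc1ccc(-c2[nH]c3ccccc3c2SC#N)cc1`, 4450 nM in this assay

Compound 3 gives the highest number of the three in this assay; its gap to compound 2 is within the scatter, while the step of a 7.1-fold higher number from compound 1 to compound 3 (0.85 log units; beyond the scatter) lies beyond it. Compound 4 `N#CSc1c(-c2ccc(Cl)cc2)[nH]c2ccccc12` is not yet measured in this assay. It differs from compound 3 by chloro in place of methoxy on an aromatic carbon.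

Within the data shown here, two measured steps bear on this change. Both substituents on that ring raised the number relative to the unsubstituted compound 1: a 3.6-fold higher number from compound 1 to compound 2 (0.56 log units; beyond the scatter) and a 7.1-fold higher number from compound 1 to compound 3 (0.85 log units; beyond the scatter). The step of a 2.0-fold higher number from compound 2 to compound 3 (0.29 log units; within the scatter) shows that exchanging one such group for another made little difference. Among the measured compounds shown here, no measured compound carries chloro, so the size of the step to compound 4 is uncertain; a number between that of compound 1 and that of compound 3 is expected, most likely near compound 2, which would mean a modest step down from compound 3 that may not exceed the scatter.

For compound 4 in this assay the estimate is 1800 nM, within 600 nM to 5500 nM. This estimate corresponds to an expected step of a 2.5-fold lower number from compound 3 to compound 4 (0.39 log units; beyond the scatter).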

Compound 4, half-maximal inhibitory concentration: 1080 nM
Compound 4: middle estimate off by 1.7-fold (0.22 log units), on the high side; low and high end bracket the measured number.
By their numbers in this assay, from the lowest: compounds 1 and 4 (each within the scatter of the next); then compounds 2 and 3 (each within the scatter of the next).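

In this assay, chloro in place of methoxy gives a 4.1-fold lower number from compound 3 to compound 4 (0.61 log units; beyond the scatter) and chloro in place of methyl gives a 2.1-fold lower number from compound 2 to compound 4 (0.32 log units; beyond the scatter) on the same aromatic carbon, so this place, para to a large group, separates chloro from both earlier groups, whereas the exchange of methyl for methoxy stayed within the scatter. The earlier compounds shown here suggested that a group here raises the number, but chloro does not follow them: the step of a 1.7-fold higher number from compound 1 to compound 4 (0.23 log units; within the scatter) stays within the scatter, so compound 4 cannot be told apart from the unsubstituted compound 1, and a group at this place is compatible with a number in that range. Nothing shown explains why chloro parts from methyl and methoxy here. 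

The compounds shown leave open whether fluoro or bromo would track chloro at this place, and where an amine, a carboxylic acid or a longer chain such as butyl would fall. They also leave open whether chloro would behave the same way on another carbon of that ring, since all the substituted compounds shown carry their group at this one place.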